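From compound 1 to compound 4: an estimate

A few compounds are considered here, and "the series" means these few. Any claim that something is new, unique, unknown or untested is made for them only; others in the source may bear on it.

Three compounds were measured in a functional assay on NCI-H460 cells (Homo sapiens) for cytotoxicity, read by MTT assay, with a stated time of 72 h; a higher number here means a weaker inhibitor, a lower number a stronger inhibitor:
compound 1 `COc1ccc(/C=N/NC(=O)Nc2ccc(Oc3ccnc(-c4nncn4CCN(C)C)c3)c(F)c2)c(OC)c1OC` gives 1790 nM
compound 2 `CN(C)CCn1cnnc1-c1cc(Oc2ccc(NC(=O)N/N=C/c3ccc(F)cc3)cc2F)ccn1` gives 1980 nM
compound 3 `CN(C)CCn1cnnc1-c1cc(Oc2ccc(NC(=O)N/N=C/c3cccc(Br)c3)cc2F)ccn1` gives 520 nM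

Compound 1 stands second highest of the three. Its nearest neighbour is compound 2, with a 1.1-fold higher number from compound 1 to compound 2 (0.04 log units; within the scatter); its furthest is compound 3, with a 3.4-fold lower number from compound 1 to compound 3 (0.54 log units; beyond the scatter). Compound 4 `COc1cc(/C=N/NC(=O)Nc2ccc(Oc3ccnc(-c4nncn4CCN(C)C)c3)c(F)c2)ccc1O` differs from compound 1 in one place: 4-hydroxy-3-methoxyphenyl in place of 2,3,4-trimethoxyphenyl on a carbon with a double bond to nitrogen. Going by the values given here, no measured step exchanges the 2,3,4-trimethoxyphenyl for a 4-hydroxy-3-methoxyphenyl, so the two steps out of compound 1 bear only loosely: the 4-fluorophenyl left the number where it was, the 3-bromophenyl brought a modest fall. Compound 4 is therefore expected to stay within the scatter of compound 1, estimated at 1500 nM (range 600 nM to 4000 nM), a step of a 1.2-fold lower number from compound 1 to compound 4 (0.08 log units; within the scatter).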

Compound 4, half-maximal inhibitory concentration: 57 nM
The estimate for compound 4 lay 26-fold (1.42 log units) above the measured number, and the stated range ends above it.
By their numbers in this assay, from the lowest: compound 4; then compound 3; then compounds 1 and 2 (each within the scatter of the next).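

In this assay, going by these compounds alone, the substituent on the carbon with a double bond to nitrogen matters far more than the earlier steps showed, with a 31-fold lower number from compound 1 to compound 4 (1.50 log units; beyond the scatter) for the 4-hydroxy-3-methoxyphenyl. Measured against the 3-bromophenyl, the 4-hydroxy-3-methoxyphenyl gives a 9.1-fold lower number from compound 3 to compound 4 (0.96 log units; beyond the scatter) and against the 4-fluorophenyl it gives a 35-fold lower number from compound 2 to compound 4 (1.54 log units; beyond the scatter) at this position. Nothing available accounts for this gain.

The compounds shown do not separate the effect of the hydroxy group from that of losing the other methoxy groups. As far as these compounds go, how a 4-hydroxyphenyl or a 4-aminophenyl would read here remains open.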